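Aryl swap on the core: chlorophenyl to fluorophenyl

The compounds below may be only part of what the source reports. "The series", "measured", "known", "first", "only" and "open" are said of these compounds alone.

Of the compounds shown here, two have numbers so far. Compound 1 `CSc1nc(-c2cccs2)c(C#N)c(=O)n1C` carries a thiophene on the shared core; in a functional assay, with a stated time of 150 min (on this read-out higher numbers stand for weaker inhibition and lower numbers for stronger inhibition), compound 1 gives 87 ug/mL. Compound 2 `CCOC(=O)c1cnn(-c2nc(-c3ccc(Cl)cc3)c(C#N)c(=O)n2C)c1N` carries a 4-chlorophenyl at the same position together with an aminopyrazole ester on the core; in this assay compound 2 gives 87 ug/mL. On the digits shown compound 2 stands level with compound 1, and the two values lie within the usual scatter of each other, so nothing of order can be read from them.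

Compound 3 `CCOC(=O)c1cnn(-c2nc(-c3ccccc3F)c(C#N)c(=O)n2C)c1N` has not been measured. Among the measured compounds shown here, its single difference from compound 2 is 2-fluorophenyl in place of 4-chlorophenyl on an aromatic carbon. For the measured compounds named here, no step between measured compounds concerns this change, so there is no basis for a directed expectation. The step of a 1.0-fold higher number from compound 2 to compound 3 (0.01 log units; within the scatter) is therefore expected to stay within the scatter, with a broad margin on either side. For compound 3 in this assay the estimate is 90 ug/mL, with a range from 40 ug/mL to 200 ug/mL.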

Compound 3, half-maximal inhibitory concentration: 87 ug/mL
Compound 3: the middle estimate sits 1.0-fold (0.01 log units) above what was measured, and the stated range covers the measured number.
By their numbers in this assay, from the lowest: compounds 1, 2 and 3 (each within the scatter of the next).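

In this assay, among the compounds shown here, 2-fluorophenyl in place of 4-chlorophenyl on the aromatic carbon ortho to a cyano group gives no change at the digits printed from compound 2 to compound 3 (within the scatter), the first step that isolates this position with the aminopyrazole ester held constant. Within this pair, the read-out shows no measurable response to this aryl exchange, although the halogen and its place on the phenyl ring change together, so the step cannot assign any contribution to either alteration alone. The data on hand offer no explanation for this flat result.

Open, on these data alone, is whether an unsubstituted phenyl, a phenyl bearing a methoxy group or an amine, or a longer chain at this position would move the number in this assay beyond the scatter, and whether chlorine and fluorine would give matching values at the same place on the phenyl ring. Also open, as far as these compounds go, is whether this position stays as flat with a carboxylic acid in place of the ethyl ester on the aminopyrazole.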